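A few compounds are considered here, and "the series" means these few. Any claim that something is new, unique, unknown or untested is made for them only; others in the source may bear on it.

Measured so far:
compound 2 `CCCCc1cn(C[C@H](O)[C@H]2OC(=O)C(OCc3ccccc3)=C2OCc2ccccc2)nn1` — 7910 nM
compound 1 `Cc1ccc(-c2cn(C/C=C3\OC(=O)C(OCc4ccccc4)=C3OCc3ccccc3)nn2)cc1` — > 100000 nM

Within the data shown here, in a functional assay on MCF7 cells (Homo sapiens) for antiproliferative activity, read by MTT assay, with a stated time of 72 h (a higher number here means a weaker inhibitor, a lower number a stronger inhibitor), compound 2 gives 7910 nM, the only number among the two values shown. Compound 1 gives > 100000 nM, which is a limit of the assay and not a number, consistent with the limit of > 100000 nM in this assay, at which 1 of the 2 values shown sits.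

Compound 3 `O=C1O[C@H]([C@@H](O)Cn2cc(CCCCl)nn2)C(OCc2ccccc2)=C1OCc1ccccc1` differs from compound 2 by chloro in place of methyl on a saturated chain carbon, three bonds along the chain from an aromatic carbon. Among the measured compounds shown here, no measured pair covers a change of this kind, so the expectation rests on compound 2 alone. The step from compound 2 to compound 3 is expected to be small, none beyond the usual scatter: a 1.0-fold higher number from compound 2 to compound 3 (0.00 log units; within the scatter). Compound 3 is therefore estimated at 8000 nM, with a range from 3000 nM to 25000 nM.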

Compound 3, half-maximal inhibitory concentration: 24500 nM
Beside the measured number, compound 3's estimate is 3.1-fold (0.49 log units) below it; measured number inside the range.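

In this assay the change from butyl to 3-chloropropyl gives a 3.1-fold higher number from compound 2 to compound 3 (0.49 log units; beyond the scatter) and shows that the far end of this chain is not a silent place in the series. The step is modest: compound 3 still gives a number, not a limit. Nothing measured here bears on the origin of this step.

From the compounds shown here alone, whether the weaker number belongs to chloro itself stays open. So does how the same chain position would respond to an amine, a carboxylic acid or a longer chain.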